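Amino for Methoxy on a Shared Core

The source may report more compounds than this note shows. Statements on the series, on what has been measured and on what is new or still open speak of the compounds shown alone.

Measured so far:
compound 1 `COc1cc(-n2c(-c3ccc(O)cc3)c[nH]c2=O)cc(OC)c1OC` gives > 50000 nM
compound 2 `COc1ccc(-c2c[nH]c(=O)n2-c2cc(OC)c(OC)c(OC)c2)cc1OC` gives "not determined" (no result reported)

Among the compounds with values here, only two compounds have been examined in a functional assay on Bel-7402 cells (Homo sapiens) for cytotoxicity, read by MTT assay, with a stated time of 48 h; a lower number here means a stronger inhibitor, a higher number a weaker inhibitor. Compound 1 returned > 50000 nM, which is a limit of the assay rather than a number. For compound 2 the result is "not determined" (no result reported), so there is no value at all to place it by. The whole of the evidence is therefore (the limit of > 50000 nM in this assay, at which 1 of the 2 values shown sits), a limit on a close relative, and compound 2 itself stands nowhere on the scale of numbers.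

Compound 3 `COc1ccc(-c2c[nH]c(=O)n2-c2cc(OC)c(OC)c(OC)c2)cc1N` differs from compound 2 by a single change: amino in place of methoxy on an aromatic carbon. With no measured step anywhere among these compounds, there is no basis for expecting a shift in this assay beyond the scatter in either direction. Compound 3 is expected to give about 30000 nM, within a range of 5000 nM to 100000 nM, with a real chance that only a limit is reported.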

Compound 3, half-maximal inhibitory concentration: > 50000 nM
Compound 3: only a limit was reported; the forecaster's own chance of this, stated with the estimate: 50%; middle value at least 1.6-fold (0.22 log units) away from the limit.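

Within the data shown here, compound 1 and compound 3 each give only a limit of the assay, and no step between them can be read. The compounds shown leave open how compound 3 compares with compound 2, which has no reported result, and whether any compound on the shared core gives an actual number in this assay.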